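A thiophene for a phenyl on a shared core

The compounds below may be only part of what the source reports. "The series", "measured", "known", "first", "only" and "open" are said of these compounds alone.

Compound 2 `Oc1cccc(-c2cc(-c3ccccc3)nc(-c3ccccc3)c2)c1` in an assay on isolated protein for inhibition of DNA topoisomerase 1 (Homo sapiens), with a stated time of 30 min, tested at 20 uM; on this read-out lower numbers stand for a weaker effect and higher numbers for a stronger effect at the one concentration tested: 0%
Compound 1 `Oc1ccccc1-c1cc(-c2ccccc2)cc(-c2ccccc2O)n1` in this assay: "not determined" (no result reported)

Two compounds share one core here, and only one of them carries a number. Compound 1 has "not determined" (no result reported) in this assay, so nothing can be said of it beyond its structure. For the measured compounds named here, compound 2 therefore stands alone in this assay, and its read-out shows no inhibition at the single concentration tested; it is the only number in the set, with no second measured compound to compare against.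

Going by the values given here, compound 3 `Oc1cccc(-c2cc(-c3ccccc3)nc(-c3cccs3)c2)c1` is the one change from compound 2 that has not yet been measured. The difference is thiophen-2-yl in place of phenyl on an aromatic carbon, next to the ring nitrogen, with a 3-hydroxyphenyl group and a phenyl group each meta to it.

Among the compounds with values here, no step between measured compounds exists to set a scale for such a swap. Given that compound 2 gives 0%, the expectation for compound 3 is a step of a number 5 percentage points higher from compound 2 to compound 3 (within the scatter), which means no change beyond the scatter. Compound 3 is estimated to reach 5% in this assay, within a range from 0% to 20%.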

Compound 3, a percentage reported as inhibition, at one concentration (the size of the read-out at that concentration, not a potency): 2%
The estimate for compound 3 lay 3 percentage points above the measured number, within the range that was stated.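

In this assay, thiophen-2-yl in place of phenyl on an aromatic carbon, next to the ring nitrogen, gives a number 2 percentage points higher from compound 2 to compound 3 (within the scatter), so the two compounds cannot be told apart on this read-out. For the compounds shown here, this is the first step that sets any scale for this position, and it shows that exchanging a six-membered aromatic ring of carbon only for a five-membered aromatic ring with one sulfur, which also brings one hydrogen-bond acceptor by count, leaves the result inside the scatter at the one concentration tested. Nothing available explains why the read-out of this pair stays so close together.

What the compounds shown leave open is whether any group on this aromatic carbon can move the read-out beyond the scatter, since a single swap between two aromatic rings says little about a group of another kind, such as an amine or a carboxylic acid. They also leave open whether the 3-hydroxyphenyl group matters to the read-out at all, since it stays the same in compound 2 and compound 3.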